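Swapping an amide for a sulfonamide on a poorly soluble core

The source may hold more compounds than are shown below. What is called first, only, known or untested is meant among the compounds shown, and "the series" means these compounds.

Of the compounds shown here, three sharing one core have been measured in a physicochemical assay for solubility, read by HPLC, with a stated time of 30 min; a lower number here means a less soluble compound, a higher number a more soluble compound. Compound 1, `CCOc1cccc(-c2csc(NC(=O)c3ccc([N+](=O)[O-])o3)n2)c1`, gives 0.34 ug/mL. Compound 2, `CC(C)Oc1cccc(-c2csc(NC(=O)c3ccc([N+](=O)[O-])o3)n2)c1`, gives 0.27 ug/mL. Compound 3, `O=C(Nc1nc(-c2cccc(NC(=O)C3CC3)c2)cs1)c1ccc([N+](=O)[O-])o1`, gives 0.47 ug/mL. Compound 3 has the highest of the three numbers, but every gap is small: a 1.4-fold higher number from compound 1 to compound 3 (0.14 log units; within the scatter) and a 1.7-fold higher number from compound 2 to compound 3 (0.24 log units; within the scatter), while a 1.3-fold lower number from compound 1 to compound 2 (0.10 log units; within the scatter). All three compounds sit in the same narrow band of low solubility.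

Compound 4, `O=C(Nc1nc(-c2cccc(NS(=O)(=O)Cc3ccccc3)c2)cs1)c1ccc([N+](=O)[O-])o1`, has not yet been measured. It differs from compound 3 in one place: benzylsulfonyl in place of cyclopropylcarbonyl on a nitrogen on an aromatic ring. Going by the values given here, the only measured steps that touch this part of the molecule are the changes from ethoxy and from isopropoxy to (cyclopropylcarbonyl)amino, and both stayed within the scatter. Among the compounds with values here, no measured compound carries a sulfonyl group or a second aromatic ring at this position, so there is no direct guide for the new group. On the evidence of steps at this position staying within the scatter, the expected change is a 1.6-fold lower number from compound 3 to compound 4 (0.19 log units; within the scatter), with no confident direction. Compound 4 is therefore estimated at 0.3 ug/mL in this assay, within a range from 0.1 ug/mL to 0.9 ug/mL.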

Compound 4, solubility: 0.48 ug/mL
The estimate for compound 4 lay 1.6-fold (0.20 log units) below the measured number, within the range that was stated.
By their numbers in this assay, from the lowest: compounds 2, 1, 3 and 4 (each within the scatter of the next).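

In this assay, putting benzylsulfonyl in place of cyclopropylcarbonyl on the nitrogen gives a 1.0-fold higher number from compound 3 to compound 4 (0.01 log units; within the scatter), even though a three-membered non-aromatic ring gives way to a six-membered aromatic ring. The comparisons with the two ether compounds agree: (benzylsulfonyl)amino in place of isopropoxy gives a 1.8-fold higher number from compound 2 to compound 4 (0.25 log units; within the scatter), and (benzylsulfonyl)amino in place of ethoxy gives a 1.4-fold higher number from compound 1 to compound 4 (0.15 log units; within the scatter), so all four groups shown at this position stay within the scatter of one another, and a sulfonyl group with a second aromatic ring has not separated itself from the rest. Nothing available explains why these numbers stay together.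

Going by these compounds, it remains open whether a group of a different kind at this position, such as an amine or a carboxylic acid, would produce a step beyond the scatter. On these data alone, all four compounds also share the same core, so the effect of a change elsewhere in it, such as replacing the nitro group, remains unknown too.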